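The compounds below may be only part of what the source reports. "The series", "measured", "known", "first", "only" and "open" are said of these compounds alone.

Working notes on the series, measured so far:

- compound 1 `Cc1c(C)c2c(c(C)c1N)CC(C)(C)O2` gives 760 nM here
- compound 2 `Cc1c(C)c2c(c(C)c1N)CC(C)(CSc1ccccc1)O2` gives 270 nM here

In a functional assay (microsomes, liver) with Rattus norvegicus as the target (on this read-out higher numbers stand for weaker inhibition and lower numbers for stronger inhibition), compound 2 stands at 270 nM as the lower of the two numbers, with compound 1 the higher. For the measured compounds named here, compound 3 `Cc1c(C)c2c(c(C)c1N)CC(C)(CSCc1ccccc1)O2` departs from compound 2 by benzyl in place of phenyl on a sulfur as its only change, benzyl in place of phenyl on a sulfur.

Going by the values given here, one measured step bears on this, a 2.8-fold lower number from compound 1 to compound 2 (0.45 log units; beyond the scatter) on bringing in phenylsulfanyl in place of hydrogen on a saturated chain carbon bound to a saturated ring carbon. That step was modest and beyond the scatter, but it shows only what bringing in the whole group did. Among the compounds with values here, no measured pair compares benzyl with phenyl on a sulfur. A move within the scatter in this assay is therefore expected, with only a slight lean toward lower numbers resting on that same step. The expected step is a 1.1-fold lower number from compound 2 to compound 3 (0.03 log units; within the scatter) and no larger move is anticipated. For compound 3 the estimated value is 250 nM with an expected range from 100 nM to 600 nM as the outcome.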

Compound 3, half-maximal inhibitory concentration: 260 nM
Compound 3: middle estimate off by 1.0-fold (0.02 log units), on the low side, and the stated range covers the measured number.
By their numbers in this assay, from the lowest: compounds 3 and 2 (each within the scatter of the next); then compound 1.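

In this assay, for the compounds shown here, benzyl in place of phenyl on a sulfur gives a 1.0-fold lower number from compound 2 to compound 3 (0.02 log units; within the scatter), the first direct comparison of two groups at this sulfur. The earlier step, a 2.8-fold lower number from compound 1 to compound 2 (0.45 log units; beyond the scatter), showed only what bringing in the whole phenylsulfanyl group did, whereas this pair shows that the read-out does not separate phenyl from benzyl at this place, so for these two groups the number does not depend on which of them sits on the sulfur. No supporting measurement bears on why the two groups read alike.

The compounds shown leave open whether the aromatic ring is needed at all, since every group on this sulfur so far carries a six-membered aromatic ring of carbon only, and a plain methyl or a longer saturated chain such as butyl could answer that. They also leave open whether a longer link such as 2-phenylethyl, a ring carrying a carboxylic acid or an amine, or an oxygen in place of the sulfur would hold the number in this assay.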